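This account rests on a few compounds, and the source may have more. Where it says the series, first, only, none or still open, it means among the compounds named here.

Of the compounds shown here, two sharing one core have been measured in a functional assay on PC-3 cells (Homo sapiens) for antiproliferative activity, read by MTT assay, with a stated time of 48 h; a higher number here means a weaker inhibitor, a lower number a stronger inhibitor. Compound 1, `C=C(/C(C)=C/c1ccc(OC)c(O)c1)c1cc(OC)c(OC)c(OC)c1`, carries a hydrogen on a double-bonded chain carbon and in this assay gives 61 nM. Compound 2, `CCC=C(/C(C)=C/c1ccc(OC)c(O)c1)c1cc(OC)c(OC)c(OC)c1`, carries an ethyl in place of that hydrogen and gives 4230 nM, the highest of the two numbers, and the step of a 69-fold higher number from compound 1 to compound 2 (1.84 log units; beyond the scatter) shows how sharply the ethyl raised the number. Compound 3, `CCCC=C(/C(C)=C/c1ccc(OC)c(O)c1)c1cc(OC)c(OC)c(OC)c1`, has not yet been measured. It differs from compound 2 by methyl in place of hydrogen on a saturated chain carbon, two bonds along the chain from a double-bonded chain carbon, so the ethyl becomes a propyl. Going by the values given here, only one measured step bears on this change: a 69-fold higher number from compound 1 to compound 2 (1.84 log units; beyond the scatter), which was large and ran toward weaker inhibition when the chain first appeared. Lengthening a chain that is already present is a smaller alteration than introducing it, so the step expected for compound 3 is moderate and in the same direction, a 1.9-fold higher number from compound 2 to compound 3 (0.28 log units; within the scatter). Compound 3 is therefore estimated at 8000 nM, with a likely range from 2500 nM to 25000 nM.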

Compound 3, half-maximal inhibitory concentration: 4510 nM
Beside the measured number, compound 3's estimate is 1.8-fold (0.25 log units) above it; low and high end bracket the measured number.
By their numbers in this assay, from the lowest: compound 1; then compounds 2 and 3 (each within the scatter of the next).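

In this assay, lengthening the ethyl to a propyl gives a 1.1-fold higher number from compound 2 to compound 3 (0.03 log units; within the scatter), so compound 2 and compound 3 cannot be told apart, and methyl in place of hydrogen on this saturated chain carbon has no readable effect. The large step seen with the ethyl is therefore not a feature of that one group: the propyl in place of hydrogen on the double-bonded chain carbon gives a 74-fold higher number from compound 1 to compound 3 (1.87 log units; beyond the scatter), close in size to a 69-fold higher number from compound 1 to compound 2 (1.84 log units; beyond the scatter). Across these three compounds, the clear difference lies between having hydrogen at this carbon and having a chain there, while the chain's growth from ethyl to propyl does not register.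

Nothing at hand explains why a chain here goes with so much weaker inhibition, or why the added carbon leaves the number within the scatter. The compounds shown also leave open how a single methyl at this carbon would compare with hydrogen, and whether a longer chain such as butyl, or a chain ending in an amine, would stay at the level of compound 2 and compound 3 or move away from it.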